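Methyl for Nitro on Two Related Ketone Cores

The source may report more compounds than this note shows. Statements on the series, on what has been measured and on what is new or still open speak of the compounds shown alone.

Compound 1, `O=C1/C(=C/c2ccccc2[N+](=O)[O-])CCc2ccccc21`: 8120 nM
Compound 2, `Cc1ccccc1/C=C1\CCc2ccccc2C1=O`: 41400 nM
Compound 3, `O=C1/C(=C/c2ccccc2[N+](=O)[O-])Cc2ccccc21`: 2540 nM

All three were tested in a functional assay on Molt4/C8 cells (Homo sapiens) for inhibition; on this read-out lower numbers stand for stronger inhibition and higher numbers for weaker inhibition. Compound 3 gives the lowest number of the three, compound 1 comes next, and compound 2 lies furthest away. Compound 1 and compound 2 differ in one place, (methyl in place of nitro on an aromatic carbon), and this change produced a 5.1-fold higher number from compound 1 to compound 2 (0.71 log units; beyond the scatter). The difference between the core of compound 1 and the core of compound 3 is not broken down here.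

Compound 4, `Cc1ccccc1/C=C1\Cc2ccccc2C1=O`, has not yet been measured in this assay. It arises from compound 3 by the same change, (methyl in place of nitro on an aromatic carbon). Because that change earlier produced a 5.1-fold higher number from compound 1 to compound 2 (0.71 log units; beyond the scatter), a step of similar size is expected here as well: a 4.7-fold higher number from compound 3 to compound 4 (0.67 log units; beyond the scatter). Compound 4 is therefore estimated at 12000 nM, expected to lie between 4500 nM and 35000 nM.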

Compound 4, half-maximal inhibitory concentration: 154000 nM
Compound 4: the middle estimate sits 13-fold (1.11 log units) below what was measured, outside the stated range (above it).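

In this assay, methyl in place of nitro on an aromatic carbon gave a 61-fold higher number from compound 3 to compound 4 (1.78 log units; beyond the scatter), so the number rose on this core as well, but the two steps differ in size: the same change on two cores in this assay, a 5.1-fold higher number (0.71 log units; beyond the scatter) from compound 1 to compound 2 and a 61-fold higher number (1.78 log units; beyond the scatter) from compound 3 to compound 4, 12-fold (1.08 log units) apart, beyond the scatter of two such steps The direction of the step therefore carried over between these two cores, while its size did not. With only two cores shown, this says nothing about how the change would behave on a further core, and it does not explain why the steps differ.

As far as these compounds go, it remains open whether the gap between the cores is particular to nitro and methyl. Other groups on the same aromatic carbon, such as an amine or a carboxylic acid, might show a similar gap or none.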